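This account rests on a few compounds, and the source may have more. Where it says the series, first, only, none or still open, it means among the compounds named here.

Measured compounds and values:
- Compound 1 `O=C(Nc1cccc(-n2cc(-c3ccncc3)c(-c3cc(O)cc(Cl)c3)n2)c1)Nc1ccc(Cl)c(C(F)(F)F)c1`; in a functional assay on KM12 cells (Homo sapiens) for inhibition, read by sulforhodamine B assay, with a stated time of 48 h, tested at 0.01 uM (a higher number here means a weaker effect of the compound at the concentration tested, a lower number a stronger effect), compound 1 gives 91%.
- Compound 2 `O=C(Nc1cccc(-n2cc(-c3ccncc3)c(-c3cc(O)cc(Cl)c3)n2)c1)Nc1ccc(Cl)c(Cl)c1`; in this assay compound 2 gives 102%.
- Compound 3 `COc1cc(Cl)cc(-c2nn(-c3cccc(NC(=O)Nc4cc(C(F)(F)F)cc(C(F)(F)F)c4)c3)cc2-c2ccncc2)c1`; in this assay compound 3 gives 97%.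

Compound 3 stands second highest of the three numbers. Its nearest neighbour is compound 2, and compound 1 is the furthest from it; both gaps are within the scatter, so compound 3 is not set apart from either. Within the data shown here, the one step beyond the scatter in the set is a number 11 percentage points higher from compound 1 to compound 2 (beyond the scatter), a modest rise.

Compound 4 `COc1cc(Cl)cc(-c2nn(-c3cccc(NC(=O)Nc4cccc(C(F)(F)F)c4)c3)cc2-c2ccncc2)c1` is not yet measured. It differs from compound 3 in one place: hydrogen in place of trifluoromethyl on an aromatic carbon. The step from compound 1 to compound 2 is the only measured one touching a trifluoromethyl group, and it exchanged that group for chloro rather than for hydrogen, so it bears on the present change only loosely. With all three measured numbers sitting high and close together in this assay, the expectation is for no step beyond the scatter, or at most a slight rise. The expected step is a number 2 percentage points higher from compound 3 to compound 4 (within the scatter). Compound 4 is estimated at 99%, with a range from 88% to 110%.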

Compound 4, a percentage reported as activity, at one concentration (the size of the read-out at that concentration, not a potency): 97%
Beside the measured number, compound 4's estimate is 2 percentage points above it, within the range that was stated.
By their numbers in this assay, from the lowest: compounds 1, 3, 4 and 2 (each within the scatter of the next, the first and the last beyond it).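

In this assay, hydrogen in place of trifluoromethyl on an aromatic carbon, at the place meta to a trifluoromethyl group in compound 3, gives no change at the digits printed from compound 3 to compound 4 (within the scatter). Among these compounds, this is the first exchange of that group for hydrogen, whereas the only earlier step touching a trifluoromethyl group put chloro in its place on a different compound, with a number 11 percentage points higher from compound 1 to compound 2 (beyond the scatter), so at this single concentration the second trifluoromethyl group of compound 3 makes no difference that can be read. No evidence on hand bears on this result.

From the compounds shown here alone, what remains open is whether any other replacement at this place, such as an amine, a carboxylic acid or a longer alkyl chain, would move the read-out beyond the scatter, or whether this place is as insensitive as the pair of compound 3 and compound 4 suggests. Also open is whether the same exchange would remain silent on the core of compound 1, which carries a hydroxy group where compound 3 and compound 4 carry a methoxy group, since the compounds shown contain no pair that isolates that difference.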